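Swapping a Piperidine for Dipropylamino on the Side Chain

The source may hold more compounds than are shown below. What is called first, only, known or untested is meant among the compounds shown, and "the series" means these compounds.

Measured in a physicochemical assay for permeability, using PAMPA; a lower number here means that the compound crosses the layer more slowly, a higher number that the compound crosses the layer faster:
- Compound 1 `Cc1ccccc1-c1nc(CN2CCC(C(=O)NCCCN3CCCC(CC(C)C)C3)CC2)c(C)o1`: 3 10^-6 cm/s
- Compound 2 `Cc1ccccc1-c1nc(CN2CCC(C(=O)NCCN3C[C@H](C)C[C@H](C)C3)CC2)c(C)o1`: 712 10^-6 cm/s

Of these two, compound 2 has the higher number, at 712 10^-6 cm/s. The next molecule, compound 3 `CCCN(CCC)CCNC(=O)C1CCN(Cc2nc(-c3ccccc3C)oc2C)CC1`, has not been measured yet. It differs from compound 2 in one place: dipropylamino in place of 3,5-dimethylpiperidin-1-yl on a saturated chain carbon, two bonds along the chain from an amide-type nitrogen. Dipropylamino, which has no ring, takes the place of 3,5-dimethylpiperidin-1-yl on a saturated chain carbon, two bonds along the chain from an amide-type nitrogen.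

For the measured compounds named here, only one measured step bears on this place: a 240-fold higher number from compound 1 to compound 2 (2.38 log units; beyond the scatter). That large step shows that a change here can matter a great deal in this assay. Both of its groups contain a ring, however, so the data do not show what a group without a ring will do. The groups in compound 2 and compound 3 are close in size, so a far smaller step is expected, and a cautious guess points downward. The estimated change is a 2.4-fold lower number from compound 2 to compound 3 (0.38 log units; beyond the scatter). For compound 3 the expected value is 300 10^-6 cm/s, with an estimated range from 60 10^-6 cm/s to 900 10^-6 cm/s.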

Compound 3, apparent permeability: 913 10^-6 cm/s
Compound 3: the middle estimate sits 3.0-fold (0.48 log units) below what was measured; the measured number lies above the stated range.
By their numbers in this assay, from the lowest: compound 1; then compounds 2 and 3 (each within the scatter of the next).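

In this assay, dipropylamino in place of 3,5-dimethylpiperidin-1-yl gives a 1.3-fold higher number from compound 2 to compound 3 (0.11 log units; within the scatter), so on this saturated chain carbon, two bonds along the chain from an amide-type nitrogen, a high number does not depend on having a ring in the group, or on the two defined stereocentres that leave with it. The large gap to the group of 11 heavy atoms in compound 1 also remains with the ringless group, as a 300-fold higher number from compound 1 to compound 3 (2.48 log units; beyond the scatter) is of the same large kind as the step already seen with compound 2, so a ring alone does not set compound 1 apart from the other two. No supporting measurement is available to explain these numbers.

The compounds shown leave open which part of the larger group in compound 1 goes with its low number, since that group differs from the other two in more than one feature. Going by these compounds, it also remains open whether a smaller dimethylamino group, or a morpholin-4-yl ring with its ring oxygen, would keep the number as high as in compound 2 and compound 3.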